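A few compounds are considered here, and "the series" means these few. Any claim that something is new, unique, unknown or untested is made for them only; others in the source may bear on it.

Measured compounds in an assay on isolated protein for inhibition of DNA topoisomerase 1 (Homo sapiens), with a stated time of 30 min, tested at 20 uM; on this read-out higher numbers stand for a stronger effect at the one concentration tested and lower numbers for a weaker effect:

compound 1, `Oc1cccc(-c2cc(-c3cccs3)cc(-c3cccc(O)c3)n2)c1`: 0%
compound 2, `Oc1ccc(-c2cc(-c3cccs3)cc(-c3cccc(O)c3)n2)cc1`: 1.1%
compound 3, `Oc1cccc(-c2cc(-c3ccoc3)cc(-c3cccc(O)c3)n2)c1`: 2%

All three share one core and differ only in the groups attached to it. In this assay none of the three separates from the others. From compound 1 to compound 2 the change is 4-hydroxyphenyl in place of 3-hydroxyphenyl on an aromatic carbon; it gives a number 1.1 percentage points higher from compound 1 to compound 2 (within the scatter). From compound 1 to compound 3 the change is furan-3-yl in place of thiophen-2-yl on an aromatic carbon; it gives a number 2 percentage points higher from compound 1 to compound 3 (within the scatter). Going by the values given here, compound 2 and compound 3 differ from each other in two places, so no single step is counted between them; their two values lie close together.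

Compound 4, `Oc1ccc(-c2cc(-c3ccoc3)cc(-c3cccc(O)c3)n2)cc1`, is not yet measured. It differs from compound 3 by 4-hydroxyphenyl in place of 3-hydroxyphenyl on an aromatic carbon. Among the compounds with values here, this is the same kind of change as the one from compound 1 to compound 2, not the same change: in compound 3 the carbon in question is meta to a furan-3-yl group, whereas in compound 1 it is meta to a thiophen-2-yl group. The step from compound 3 to compound 4 in this assay is expected to be a number 0.5 percentage points higher from compound 3 to compound 4 (within the scatter), set beside the earlier a number 1.1 percentage points higher from compound 1 to compound 2 (within the scatter), and it rests on that one earlier instance together with the flat read-outs of all three measured compounds. Compound 4 is therefore estimated to give 2.5%, with an expected range from 0% to 9%.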

Compound 4, a percentage reported as inhibition, at one concentration (the size of the read-out at that concentration, not a potency): 1.3%
Estimate against measurement, compound 4: 1.2 percentage points above; low and high end bracket the measured number.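

In this assay, going by these compounds alone, 4-hydroxyphenyl in place of 3-hydroxyphenyl gives a number 0.7 percentage points lower from compound 3 to compound 4 (within the scatter), and this step does not differ from its earlier counterpart on the other core: the same change on two cores in this assay, a number 1.1 percentage points higher (within the scatter) from compound 1 to compound 2 and a number 0.7 percentage points lower (within the scatter) from compound 3 to compound 4, 1.8 percentage points apart, within the scatter of two such steps Furan-3-yl in place of thiophen-2-yl gives a number 0.2 percentage points higher from compound 2 to compound 4 (within the scatter), and the two instances of this change likewise do not differ: the same change on two cores in this assay, a number 2 percentage points higher (within the scatter) from compound 1 to compound 3 and a number 0.2 percentage points higher (within the scatter) from compound 2 to compound 4, 1.8 percentage points apart, within the scatter of two such steps Each change therefore carries from one core to the other without a visible difference, but this shows only that neither change separates the compounds at the one concentration tested; with all four read-outs lying close together near zero, it does not show that either change would carry over the same way on a compound with a clear effect.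

The compounds shown leave open whether any group on the shared core can lift the read-out beyond the scatter, since they hold only hydroxyphenyl groups together with thiophen-2-yl or furan-3-yl. An amine or a carboxylic acid in place of a hydroxyl group, or a longer chain in place of furan-3-yl, remains an open case, as does the effect of these compounds at any other concentration, which a read-out at one concentration cannot give.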